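This account rests on a few compounds, and the source may have more. Where it says the series, first, only, none or still open, it means among the compounds named here.

Measured in a functional assay on K562 cells (Homo sapiens) for antiproliferative activity, read by MTT assay, with a stated time of 5 days; a higher number here means a weaker inhibitor, a lower number a stronger inhibitor:
- Compound 1 `COc1ccc(C(=Cc2ccc(OC)c([N+](=O)[O-])c2)C(=O)c2cc(OC)c(OC)c(OC)c2)cc1`: 2660000 nM
- Compound 2 `COc1ccc(C=C(C(=O)c2cc(OC)c(OC)c(OC)c2)c2ccccc2)cc1[N+](=O)[O-]`: > 10000000 nM (a limit)

Compound 2 gives no number in this assay, only a limit: the limit of > 10000000 nM in this assay, at which 1 of the 2 values shown sits. Compound 3 `COc1ccc(C=C(C(=O)c2cc(OC)c(OC)c(OC)c2)c2ccc(C)cc2)cc1[N+](=O)[O-]` differs from compound 2 by methyl in place of hydrogen on an aromatic carbon, with methyl in place of hydrogen on an aromatic carbon, para to a large group. Within the data shown here, the one measured step that bears on this is an at least 3.7-fold higher number from compound 1 to compound 2 (0.57 log units; beyond the scatter), with hydrogen in place of methoxy on an aromatic carbon, and it lies beyond the scatter. Compound 1 has methoxy at that place and shows 2660000 nM, so a modest fall in the number is expected on adding methyl there. Even so, compound 3 may well meet the limit again. The expected step is an at least 2.0-fold lower number from compound 2 to compound 3 (0.30 log units; that floor lies within the scatter). Compound 3 is estimated at 5000000 nM, with an expected range from 1500000 nM to 15000000 nM.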

Compound 3, half-maximal inhibitory concentration: 2430000 nM
Compound 3: the middle estimate sits 2.1-fold (0.31 log units) above what was measured; measured number inside the range.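

In this assay, among these compounds, methyl on the phenyl ring gives an at least 4.1-fold lower number from compound 2 to compound 3 (0.61 log units; beyond the scatter), so the gain from filling this place with a group is not confined to methoxy, the only group there until now. The step between the two filled compounds is a 1.1-fold lower number from compound 1 to compound 3 (0.04 log units; within the scatter), so methyl and methoxy at this place cannot be told apart in this assay, although one holds an oxygen and the other does not. The true size of the gain over hydrogen stays unknown, and only its floor can be read, since compound 2 carries a limit and not a number: the limit of > 10000000 nM in this assay, at which 1 of the 3 values shown sits.

The compounds shown hold only hydrogen, methyl and methoxy at this place, so it remains open how a chlorine atom, an amine or a carboxylic acid there would compare. Going by these compounds, it is also open whether a longer chain, such as ethyl or propyl, would keep the same level or move away from it.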